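Chloro to fluoro on the pendant phenyl of compound 3

A few compounds are considered here, and "the series" means these few. Any claim that something is new, unique, unknown or untested is made for them only; others in the source may bear on it.

In an ADME assay on microsomes from liver (Homo sapiens) for metabolic stability, tested at 2.5 uM (a lower number here means slower removal, a higher number faster removal of the compound), compound 3, `O=S(=O)(c1cccc(F)c1)c1cnc2c(F)cccc2c1-c1ccc(Cl)cc1`, gives 0.62 mL/min, the second highest of the three numbers at hand. Compound 1, `O=S(=O)(c1ccc(F)c(Cl)c1)c1cnc2c(F)cccc2c1-c1ccc(F)cc1`, gives 0.19 mL/min, and compound 2, `Cc1ccc(S(=O)(=O)c2cnc3c(F)cccc3c2-c2ccc(F)cc2)cc1F`, gives 2.75 mL/min, so compound 3 sits between them, beyond the scatter from each. Within the data shown here, the one step measured so far, a 14-fold higher number from compound 1 to compound 2 (1.16 log units; beyond the scatter), concerns the aryl on the sulfonyl sulfur and not the ring touched here. Compound 4, `O=S(=O)(c1cccc(F)c1)c1cnc2c(F)cccc2c1-c1ccc(F)cc1`, differs from compound 3 by fluoro in place of chloro on an aromatic carbon, that is 4-chlorophenyl to 4-fluorophenyl. Among the measured compounds shown here, no measured step covers this exchange, so the expectation rests on compound 3 alone and on the likeness of compound 4 to compound 1, which shares the 4-fluorophenyl and gives the lowest number. Compound 4 is therefore expected to show a modest shift, a 1.4-fold lower number from compound 3 to compound 4 (0.14 log units; within the scatter), toward a lower number in this assay. The estimated value of compound 4 is 0.45 mL/min, within a range from 0.2 mL/min to 1 mL/min.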

Compound 4, intrinsic clearance in a liver preparation (reported as CLH), per the amount of preparation that the assay uses: 0.19 mL/min
The estimate for compound 4 lay 2.4-fold (0.37 log units) above the measured number, outside the stated range (below it).
By their numbers in this assay, from the lowest: compounds 1 and 4 (each within the scatter of the next); then compound 3; then compound 2.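

In this assay the 4-chlorophenyl to 4-fluorophenyl exchange gives a 3.3-fold lower number from compound 3 to compound 4 (0.51 log units; beyond the scatter), which shows that the number responds to this halogen and not only to the aryl on the sulfonyl sulfur. On that sulfonyl aryl, hydrogen in place of methyl gives a 14-fold lower number from compound 2 to compound 4 (1.16 log units; beyond the scatter), while dropping the chloro and the second fluoro leaves no change at the digits printed from compound 1 to compound 4 (within the scatter), so among these compounds only the methyl-bearing compound 2 stands far from compound 1 and compound 4. Nothing measured alongside these numbers accounts for either step.

As far as these compounds go, whether a methoxy group or an amine on that carbon of the phenyl ring would give a number apart from those of chloro and fluoro stays open. So does whether the chloro-to-fluoro step keeps its size when the methyl-bearing aryl sits on the sulfonyl sulfur.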